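Triazole ethers: anilide pair, methoxy position moved

The source may hold more compounds than are shown below. What is called first, only, known or untested is meant among the compounds shown, and "the series" means these compounds.

Measured so far:
compound 1 `COc1ccccc1-n1cc(COc2ccc3c(c2)CCC3)nn1` — 19.8%
compound 2 `COc1ccc(NC(=O)Cn2cc(COc3ccc4c(c3)CCC4)nn2)cc1` — "not determined" (no result reported)
compound 3 `Cc1ccc([N+](=O)[O-])cc1-n1cc(COc2ccc3c(c2)CCC3)nn1` — 26.5%

In an ADME assay on HEK293 cells (Homo sapiens) for inhibition, read by MTT assay, with a stated time of 48 h, tested at 25 uM (on this read-out lower numbers stand for less inhibition and higher numbers for more inhibition at the one concentration tested (going by the name of the read-out)), compound 1 gives 19.8% and compound 3 gives 26.5%; the gap between these two lies within the usual scatter, so neither can be ranked against the other. Compound 2 carries the anilide linker instead of the direct aryl link of compounds 1 and 3, and in this assay compound 2 shows "not determined" (no result reported), so there is nothing to place it on.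

Compound 4 `COc1ccccc1NC(=O)Cn1cc(COc2ccc3c(c2)CCC3)nn1` is the unmeasured partner of compound 2; the difference is 2-methoxyphenyl in place of 4-methoxyphenyl on an amide-type nitrogen. For the measured compounds named here, no measured pair shows this change, so no step size can be read off. Since the two directly linked aryl compounds sit close together regardless of their substitution, the expectation for compound 4 is a value in the same low region, with no direction beyond the scatter. Compound 4 is estimated at 23%, in a range from 5% to 45%.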

Compound 4, a percentage reported as inhibition, at one concentration (the size of the read-out at that concentration, not a potency): 23.4%
Estimate against measurement, compound 4: 0.4 percentage points below; measured number inside the range.
By their numbers in this assay, from the lowest: compounds 1, 4 and 3 (each within the scatter of the next).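

For the compounds shown here, compound 2 has no reported number in this assay, so no step to compound 4, at 23.4%, can be read. The compounds shown leave open whether 2-methoxyphenyl in place of 4-methoxyphenyl on an amide-type nitrogen shifts this read-out at all. No supporting data bear on this result.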